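The source may report more compounds than this note shows. Statements on the series, on what has been measured and on what is new or still open speak of the compounds shown alone.

Measured compounds:
- compound 1, `COc1nc(C(C)(C)C)ccc1[C@@H](c1ccccc1)[C@@](O)(CCN(C)C)c1cccc2ccccc12`: > 64 ug/mL
- compound 2, `COc1nc(-c2ccccc2F)ccc1[C@@H](c1ccccc1)[C@@](O)(CCN(C)C)c1cccc2ccccc12`: "nd" (no result reported)

Two compounds of this shared core have been put into a toxicity assay on HeLa cells (Homo sapiens) for cytotoxicity; on this read-out lower numbers stand for higher toxicity in this test and higher numbers for lower toxicity in this test. Compound 1 reaches only the limit of the test, > 64 ug/mL, which is not a number but the edge of what the assay can read. Compound 2 stands without any number in this assay, so where it lies can only be judged from compound 1, whose result sits at the limit of > 64 ug/mL in this assay, at which 1 of the 2 values shown sits.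

Compound 3, `COc1nc(-c2ccc(Br)cc2)ccc1[C@@H](c1ccccc1)[C@@](O)(CCN(C)C)c1cccc2ccccc12`, has not been measured yet. It differs from compound 2 by 4-bromophenyl in place of 2-fluorophenyl on an aromatic carbon. Within the data shown here, no measured pair in this set changes a group in the same way, so the size of this step is not known from the data; with compound 1 sitting at the limit, any step of this kind would be hidden if compound 3 also landed there. The expectation is a value that stays near the upper end of the test, with a good chance that only a limit is reported again. Compound 3 is therefore estimated at 50 ug/mL in this assay, in a range from 16 ug/mL to 100 ug/mL.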

Compound 3, half-maximal cytotoxic concentration: > 64 ug/mL
Compound 3: a limit, no number; the forecaster's own chance of this, stated with the estimate: 55%; middle value at least 1.2-fold (0.10 log units) from the limit.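

In this assay, no step can be read between compound 1 and compound 3, because both results are limits and not numbers: the limit of > 64 ug/mL in this assay, at which 2 of the 3 values shown sit.

The compounds shown leave open how toxic compound 1 and compound 3 are to these cells, whether swapping these groups changes that toxicity at all, and where compound 2 stands.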